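Trading a Trifluoromethylphenyl Group for a Cyanopyridine

The compounds below may be only part of what the source reports. "The series", "measured", "known", "first", "only" and "open" are said of these compounds alone.

Three compounds have been measured so far:
- Compound 1, `COc1cncc(-c2c(C)nn(-c3nc(-c4ccc(Cl)c(Cl)c4)c(SC(C)C)s3)c2C(=O)O)c1`, gives 21000 nM in a functional assay on BJAB cells (Homo sapiens) for antiproliferative activity, with a stated time of 4 days; a lower number here means that less compound is needed, a higher number that more compound is needed for the effect.
- Compound 2, `CCOc1ncccc1-c1c(C)nn(-c2nc(-c3ccc(Cl)c(Cl)c3)c(SC(C)C)s2)c1C(=O)O`, gives 11000 nM in this assay.
- Compound 3, `Cc1nn(-c2nc(-c3ccc(Cl)c(Cl)c3)c(SC(C)C)s2)c(C(=O)O)c1-c1ccccc1C(F)(F)F`, gives 5200 nM in this assay.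

All three share one core and differ only in the aromatic group attached to it. Compound 3 stands lowest of the three numbers: the step of a 2.1-fold lower number from compound 2 to compound 3 (0.33 log units; beyond the scatter) is modest but beyond the scatter, and the step of a 4.0-fold lower number from compound 1 to compound 3 (0.61 log units; beyond the scatter) is larger, while the step of a 1.9-fold lower number from compound 1 to compound 2 (0.28 log units; within the scatter) between the two pyridine-bearing compounds lies within the scatter.

Compound 4, `Cc1nn(-c2nc(-c3ccc(Cl)c(Cl)c3)c(SC(C)C)s2)c(C(=O)O)c1-c1cncc(C#N)c1`, has not yet been measured. Its change from compound 3 is 5-cyanopyridin-3-yl in place of 2-(trifluoromethyl)phenyl on an aromatic carbon. Both measured steps that end at compound 3 bear on this: each replaced a pyridine ring carrying a small substituent with the 2-(trifluoromethyl)phenyl group and each lowered the number in this assay. Compound 4 reverses that direction, returning to a pyridine ring, now bearing a nitrile. The number for compound 4 is therefore expected to rise again, by about a 2.3-fold higher number from compound 3 to compound 4 (0.36 log units; beyond the scatter), landing near the two earlier pyridine compounds. Compound 4 is estimated at 12000 nM, with a likely range from 4000 nM to 35000 nM.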

Compound 4, half-maximal effective concentration: 20000 nM
Beside the measured number, compound 4's estimate is 1.7-fold (0.22 log units) below it, and the stated range covers the measured number.
By their numbers in this assay, from the lowest: compound 3; then compounds 2, 4 and 1 (each within the scatter of the next).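

In this assay, placing 5-cyanopyridin-3-yl on the aromatic carbon gives a 3.8-fold higher number from compound 3 to compound 4 (0.59 log units; beyond the scatter), so all three pyridine-bearing compounds now stand beyond the scatter above the 2-(trifluoromethyl)phenyl compound, and none of the four goes against this. The nature of the pyridine group shows no clear effect so far: a 1.8-fold higher number from compound 2 to compound 4 (0.26 log units; within the scatter) and a 1.1-fold lower number from compound 1 to compound 4 (0.02 log units; within the scatter) both lie within the scatter, so exchanging methoxy for a nitrile on the same ring leaves the result unresolved. No measurement at hand explains the gap between the pyridine compounds and compound 3.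

The entering and leaving groups differ in both the ring and its substituent, so the compounds shown cannot say whether the ring nitrogen or the trifluoromethyl group accounts for the lower number of compound 3. An unsubstituted phenyl ring, a phenyl ring carrying a nitrile, or a pyridine ring carrying trifluoromethyl would separate these two parts of the change, while a pyridine ring carrying an amine would extend the small set of substituents seen here.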